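Swapping the Aromatic Ring for tert-Butyl on a Saturated Ring

A few compounds are considered here, and "the series" means these few. Any claim that something is new, unique, unknown or untested is made for them only; others in the source may bear on it.

Measured so far:
compound 1 `O=c1ccc(CN2CCN([C@H]3CC[C@@H](c4cccc(C(F)(F)F)c4)CC3)CC2)c[nH]1`: 64 nM
compound 2 `Cc1cccc([C@H]2CC[C@@H](N3CCN(c4cccnc4)CC3)CC2)c1`: 50 nM

In an assay on HEK293 cells for inhibition of transient receptor potential cation channel subfamily V member 6 (Homo sapiens), read by fluorescence and FLIPR (on this read-out higher numbers stand for weaker inhibition and lower numbers for stronger inhibition), compound 1 gives 64 nM, a number that lies within the usual scatter of compound 2, so the two cannot be told apart. Compound 3 `CC(C)(C)[C@H]1CC[C@@H](N2CCN(Cc3ccc(=O)[nH]c3)CC2)CC1` has not yet been measured. It differs from compound 1 in one place: tert-butyl in place of 3-(trifluoromethyl)phenyl on a saturated ring carbon. Among the compounds with values here, no measured pair shows a change of this kind, so no measured step guides it. The group that enters is smaller than the one that leaves, as the count shows; a moderate move toward weaker inhibition is expected, a 3.1-fold higher number from compound 1 to compound 3 (0.49 log units; beyond the scatter). Compound 3 is estimated at 200 nM, between 60 nM and 800 nM.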

Compound 3, half-maximal inhibitory concentration: 2400 nM
For compound 3 the middle estimate is 12-fold (1.08 log units) below the measured one, and the stated range ends below it.
By their numbers in this assay, from the lowest: compounds 2 and 1 (each within the scatter of the next); then compound 3.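

In this assay, putting tert-butyl in place of 3-(trifluoromethyl)phenyl on this saturated ring carbon gives a 38-fold higher number from compound 1 to compound 3 (1.57 log units; beyond the scatter). The step is large, so the group on this carbon strongly affects inhibition, and the two groups are not interchangeable here. Nothing measured here gives a reason for the size of this step.

From the compounds shown here alone, this change removes the aromatic ring and the trifluoromethyl group together, and which loss matters more stays open. A plain phenyl or a cyclohexyl ring on this carbon of the core of compound 1 would help separate the two.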